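The source may report more compounds than this note shows. Statements on the series, on what has been measured and on what is new or still open speak of the compounds shown alone.

In an ADME assay on MT2 cells (Homo sapiens) for cytotoxicity, read by XTT assay, with a stated time of 4 days (on this read-out higher numbers stand for lower toxicity in this test and lower numbers for higher toxicity in this test), compound 1 `Cc1nc(C(NC(=O)C(=O)Nc2ccc(Cl)cc2)C2CCCCN2)sc1CO` gives > 108000 nM as a limit of the assay. Likewise compound 2 `Cc1ccc(NC(=O)C(=O)NC(c2nc(C)c(CO)s2)C2CCCCN2)cc1F` gives > 88000 nM as a limit, so it stands without a true number. Compound 3 `Cc1nc(C(NC(=O)C(=O)Nc2ccc(F)cc2)C2CCCCN2)sc1CO` differs from compound 2 by 4-fluorophenyl in place of 3-fluoro-4-methylphenyl on an amide-type nitrogen in one place, with 4-fluorophenyl in place of 3-fluoro-4-methylphenyl on an amide-type nitrogen. Among the compounds with values here, the only measured step that the two limits leave unreadable from compound 1 to compound 2 gives no size to carry over, so no change beyond the scatter is expected in this assay in either direction. The estimated step is a step that the limit leaves unreadable from compound 2 to compound 3 for now. For compound 3 the expected value is 100000 nM with an estimated range of 40000 nM to 200000 nM as its span.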

Compound 3, half-maximal cytotoxic concentration: > 113000 nM
Compound 3 ended at the assay's limit; the forecaster's own chance of this, stated with the estimate: 85%; middle value at least 1.1-fold (0.05 log units) away from the limit.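

Within the data shown here, compound 1, compound 2 and compound 3 each give only a limit in this assay, so no step among them can be read. The compounds shown leave open where their true half-maximal cytotoxic concentrations lie and whether the group on the amide-type nitrogen changes them.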